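This account rests on a few compounds, and the source may have more. Where it says the series, first, only, none or still open, it means among the compounds named here.

Measured in a functional assay on T47D cells (Homo sapiens) for antiproliferative activity, read by MTT assay, with a stated time of 48 h; on this read-out lower numbers stand for stronger inhibition and higher numbers for weaker inhibition:

Compound 1 `Cc1cccc2[nH]c(-c3cc4ccccc4n3Cc3ccccc3)nc12`: "not determined" (no result reported)
Compound 2 `Cc1cc(C)c2nc(-c3cc4ccccc4n3Cc3ccccc3)[nH]c2c1`: 21800 nM
Compound 3 `c1ccc(Cn2c(-c3nc4ccccc4[nH]3)cc3ccccc32)cc1`: 21500 nM
Compound 4 `Cc1cccc2[nH]c(-c3cc4ccccc4[nH]3)nc12`: not yet measured

Compound 1 has no number to stand on, since its entry reads "not determined" (no result reported). Its position can only be judged from its two relatives, which also carry the benzyl group on the aromatic nitrogen. Compound 2 at 21800 nM and compound 3 at 21500 nM lie within the usual scatter of each other, and both sit in a weak range.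

Compound 4 is compound 1 with hydrogen in place of benzyl on an aromatic nitrogen. Within the data shown here, no measured compound here lacks the benzyl group, so the size of this step is a judgement and not a reading. In this assay a moderate step towards weaker inhibition is expected, though one that might barely clear the scatter.

For compound 4 the estimated value is 35000 nM, with an expected range from 12000 nM to 90000 nM.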

Compound 4, half-maximal inhibitory concentration: 8900 nM
The estimate for compound 4 lay 3.9-fold (0.59 log units) above the measured number, outside the stated range (below it).
By their numbers in this assay, from the lowest: compound 4; then compounds 3 and 2 (each within the scatter of the next).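

In this assay compound 4 gives 8900 nM, but compound 1 has no number, so the step between compound 1 and compound 4 cannot be read. No evidence at hand bears on this result. The compounds shown leave open how much hydrogen in place of benzyl on the aromatic nitrogen changes inhibition.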